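A few compounds are considered here, and "the series" means these few. Any claim that something is new, unique, unknown or untested is made for them only; others in the source may bear on it.

In a functional assay on PC-3 cells (Homo sapiens) for cytotoxicity, read by MTT assay (a higher number here means a weaker inhibitor, a lower number a stronger inhibitor), compound 1 `C[Se]/C(=N\C(=O)c1ccc(Cl)nc1)NC(=O)c1ccc(Cl)nc1` gives 9140 nM. In this assay compound 3 `C[Se]/C(=N\C(=O)c1ccccc1)NC(=O)c1ccccc1` gives 2500 nM. For compound 2 `CS/C(=N\C(=O)c1ccccc1)NC(=O)c1ccccc1` the result in this assay is a limit of the assay, > 10000 nM.

Compound 3 gives the lowest of the two numbers, and compound 1 a higher one. Compounds 2 and 3 differ in one place, where an at least 4.0-fold lower number from compound 2 to compound 3 (0.60 log units; beyond the scatter); the value of compound 2 is a limit, (the limit of > 10000 nM in this assay, at which 1 of the 3 values shown sits). Compound 4 `CC[Se]/C(=N\C(=O)c1ccccc1)NC(=O)c1ccccc1` differs from compound 3 by methyl in place of hydrogen on a saturated chain carbon bound to a selenium atom. Going by the values given here, no measured step touches the chain on the selenium; the single measured step exchanges the sulfur for selenium instead. The expected change in this assay is therefore none beyond the scatter, no change at the digits printed from compound 3 to compound 4 (within the scatter). Compound 4 is estimated at 2500 nM, between 1000 nM and 6500 nM.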

Compound 4, half-maximal inhibitory concentration: > 10000 nM
Compound 4: no number, only a limit (the forecaster's own chance of this, stated with the estimate: 8%); at least 4.0-fold (0.60 log units) between middle value and limit.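

The chain on the selenium turns out to matter in this assay: methyl in place of hydrogen on a saturated chain carbon bound to a selenium atom gives an at least 4.0-fold higher number from compound 3 to compound 4 (0.60 log units; beyond the scatter). Until now, only the exchange of sulfur for selenium had been seen to move the number, and the value of compound 4 is a limit. The step from compound 2 to compound 4 cannot be read, since both values are limits: the limit of > 10000 nM in this assay, at which 2 of the 4 values shown sit.

On these data alone, whether a longer chain on the selenium, such as propyl, would stay at this limit remains open. So does whether an amine at the end of that chain would restore the activity.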